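Working notes: from compound 3 to compound 4

The source may hold more compounds than are shown below. What is called first, only, known or untested is meant among the compounds shown, and "the series" means these compounds.

Measured in a functional assay on K562 cells (Homo sapiens) for antiproliferative activity, read by MTT assay; on this read-out higher numbers stand for weaker inhibition and lower numbers for stronger inhibition:
- compound 1 `O=C(CCCCCNC(=S)NN=C(c1ccccc1)c1ccccc1)NO`: 3810 nM
- compound 2 `Cc1ccccc1/C(=N/NC(=S)NCCCCCC(=O)NO)c1ccccc1`: 3510 nM
- compound 3 `Cc1ccc(/C(=N/NC(=S)NCCCCCC(=O)NO)c2ccccc2)cc1`: 4340 nM

Compound 3 at 4340 nM lies within the scatter of both compound 1 and compound 2, so the three values do not separate. The next structure, compound 4 `O=C(CCCCCNC(=S)N/N=C(\c1ccccc1)c1ccccc1F)NO`, has 2-fluorophenyl in place of 4-methylphenyl on a carbon with a double bond to nitrogen. Within the data shown here, no measured compound carries 2-fluorophenyl, so the evidence is indirect. Among the measured compounds shown here, three measured steps bear on the change: a 1.1-fold lower number from compound 1 to compound 2 (0.04 log units; within the scatter), a 1.1-fold higher number from compound 1 to compound 3 (0.06 log units; within the scatter) and a 1.2-fold higher number from compound 2 to compound 3 (0.09 log units; within the scatter). All three stay within the scatter, so no shift beyond it is expected. The estimated step is a 1.1-fold lower number from compound 3 to compound 4 (0.06 log units; within the scatter). For compound 4 the expected value is 3800 nM, with an estimated range of 2200 nM to 6500 nM.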

Compound 4, half-maximal inhibitory concentration: 4630 nM
Beside the measured number, compound 4's estimate is 1.2-fold (0.09 log units) below it, and the stated range covers the measured number.
By their numbers in this assay, from the lowest: compounds 2, 1, 3 and 4 (each within the scatter of the next).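

In this assay, 2-fluorophenyl on a carbon with a double bond to nitrogen gives no separation by any of the three routes: (a 1.1-fold higher number from compound 3 to compound 4 (0.03 log units; within the scatter)), (a 1.3-fold higher number from compound 2 to compound 4 (0.12 log units; within the scatter)) and (a 1.2-fold higher number from compound 1 to compound 4 (0.08 log units; within the scatter)). Fluoro on an aromatic carbon therefore joins methyl in leaving the number within the scatter of the unsubstituted compound 1. No available data explain this flat result.

Going by these compounds, it remains open whether an amine or a carboxylic acid on an aromatic carbon would shift the number beyond the scatter. On these data alone, the effect of a longer chain in place of the one in the shared core is also open.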